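Replacing an ethyl group with a halogenated aryl carbamate

The source may report more compounds than this note shows. Statements on the series, on what has been measured and on what is new or still open speak of the compounds shown alone.

Measured compounds:
- compound 1, `CCOc1cc(=O)n(CCCO)c2c1CC(CC=C(C)C)C(C)(C)C2`: 66.5%
- compound 2, `COc1ccc(NC(=O)Oc2cc(=O)n(CCCO)c3c2CC(CC=C(C)C)C(C)(C)C3)cc1`: 3.7%
- compound 3, `CC(C)=CCC1Cc2c(OC(=O)Nc3ccccc3F)cc(=O)n(CCCO)c2CC1(C)C`: 52.3%

In a functional assay on PANC-1 cells (Homo sapiens) for inhibition, read by MTT assay, with a stated time of 24 h, tested at 10 uM (on this read-out lower numbers stand for less inhibition and higher numbers for more inhibition at the one concentration tested (going by the name of the read-out)), compound 1 gives 66.5%, the highest of the three numbers; compound 3 comes nearest and compound 2 lies furthest away. Both other compounds carry an aryl carbamoyl group in place of the ethyl on the oxygen on the aromatic ring of the shared core. The two steps from compound 1 bear directly on the new compound: a number 62.8 percentage points lower from compound 1 to compound 2 (beyond the scatter) and a number 14.2 percentage points lower from compound 1 to compound 3 (beyond the scatter). The comparison between the two aryl groups, a number 48.6 percentage points higher from compound 2 to compound 3 (beyond the scatter), shows how strongly the identity of the aryl ring matters.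

Compound 4, `CC(C)=CCC1Cc2c(OC(=O)Nc3ccc(F)c(Cl)c3)cc(=O)n(CCCO)c2CC1(C)C`, is not yet measured. It differs from compound 1 as follows: (3-chloro-4-fluorophenyl)carbamoyl in place of ethyl on an oxygen on an aromatic ring. Because a number 62.8 percentage points lower from compound 1 to compound 2 (beyond the scatter) and a number 14.2 percentage points lower from compound 1 to compound 3 (beyond the scatter) both point downward but differ widely in size, a drop beyond the scatter is expected for compound 4 as well, its size uncertain. For compound 4 the expected step is a number 31.5 percentage points lower from compound 1 to compound 4 (beyond the scatter). The estimate for compound 4 is therefore 35%, within a range from 5% to 62%.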

Compound 4, a percentage reported as inhibition, at one concentration (the size of the read-out at that concentration, not a potency): 79.8%
Compound 4: the middle estimate sits 44.8 percentage points below what was measured; measured number above the stated range.
By their numbers in this assay, from the lowest: compound 2; then compound 3; then compound 1; then compound 4.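

In this assay, swapping ethyl for an aryl carbamoyl group on the oxygen on the aromatic ring need not lower the number: (3-chloro-4-fluorophenyl)carbamoyl gives a number 13.3 percentage points higher from compound 1 to compound 4 (beyond the scatter) and so reverses the downward direction seen with compound 2 and compound 3. With the carbamate link kept, 3-chloro-4-fluorophenyl in place of 2-fluorophenyl gives a number 27.5 percentage points higher from compound 3 to compound 4 (beyond the scatter) and, in place of 4-methoxyphenyl, gives a number 76.1 percentage points higher from compound 2 to compound 4 (beyond the scatter) in the same assay. The carbamate link alone therefore does not set the outcome at this position, since compound 2, compound 3 and compound 4 all carry it and their numbers still spread widely, so the aryl ring attached to it has to be considered as well.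

A phenyl ring carrying chlorine alone or fluorine alone would separate the two halogens of compound 4, while a butyl chain or a ring bearing a carboxylic acid in place of the 3-chloro-4-fluorophenyl would show whether an aryl ring of this kind is needed at all. Nothing measured alongside these numbers explains why the aryl ring changes them so strongly.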